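The source may report more compounds than this note shows. Statements on the series, on what has been measured and on what is new or still open speak of the compounds shown alone.

The shared core of compound 1 `CC(=O)Nc1ccc(S(=O)(=O)NNC(=O)c2cccnc2Nc2ccc(Cl)cc2)cc1` carries a sulfonyl hydrazide linked to a pyridine bearing a 4-chloroanilino group. In a functional assay on RXF 393 cells (Homo sapiens) for antiproliferative activity (a higher number here means that more compound is tolerated, a lower number that less compound is tolerated), compound 1 sits at the upper limit of what the measurement can report, giving > 100000 nM, which is a limit and not a number. A related compound 2 `O=C(NNS(=O)(=O)c1ccc(F)cc1)c1cccnc1Nc1ccc(Cl)cc1Cl` differs in two places at once, and in this assay compound 2 gives 66100 nM. Among the compounds with values here, no single-place step between measured compounds exists here, so compound 1 stands only as a limit (the limit of > 100000 nM in this assay, at which 1 of the 2 values shown sits).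

Compound 3 `O=C(NNS(=O)(=O)c1ccc(Cl)cc1Cl)c1cccnc1Nc1ccc(Cl)cc1` has not yet been measured. It differs from compound 1 by 2,4-dichlorophenyl in place of 4-acetamidophenyl on a sulfonyl sulfur. The step from compound 1 to compound 3 is expected to move the number downward, that is, toward less compound being tolerated, though the size of that move cannot be pinned against a limit; the estimated step is an at least 2.0-fold lower number from compound 1 to compound 3 (0.30 log units; that floor lies within the scatter). Compound 3 is expected to give about 50000 nM in this assay, within a range from 15000 nM to 150000 nM, with a real chance that only a limit is reported again.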

Compound 3, concentration lethal to 50% of the cells: > 100000 nM
Compound 3: a limit, no number; the forecaster's own chance of this, stated with the estimate: 40%; middle value at least 2.0-fold (0.30 log units) away from the limit.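

Within the data shown here, compound 3, like compound 1, gives only a limit and not a number in this assay, so no step from compound 1 to compound 3 can be read: the limit of > 100000 nM in this assay, at which 2 of the 3 values shown sit.
In this assay the compounds shown leave open how far, and even in which direction, 2,4-dichlorophenyl in place of 4-acetamidophenyl on a sulfonyl sulfur moves the number.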